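A few compounds are considered here, and "the series" means these few. Any claim that something is new, unique, unknown or untested is made for them only; others in the source may bear on it.

In a functional assay on HepG2 cells (Homo sapiens) for antiproliferative activity, read by MTT assay, with a stated time of 48 h; a lower number here means a stronger inhibitor, a higher number a weaker inhibitor:

- compound 1 `COc1ccccc1NC(=O)Nc1cccc(CNc2nccnc2Cl)c1`: 13700 nM
- compound 2 `O=C(Nc1cccc(CNc2nccnc2Cl)c1)NC1CCCCC1`: > 40000 nM, which is a limit of the assay and not a number
- compound 3 `Cc1ccc(NC(=O)Nc2cccc(CNc3nccnc3Cl)c2)cc1`: 11500 nM

For the measured compounds named here, compound 3 and compound 1 are the only two with measured numbers, and they lie within the scatter of each other. The next compound, compound 4 `Cc1ccc(NC(=O)Nc2cccc(CNc3nccnc3Cl)c2)cc1Cl`, changes compound 3 in one place: a chloro replaces a hydrogen on an aromatic carbon, ortho to a methyl group, turning 4-methylphenyl into 3-chloro-4-methylphenyl (chloro in place of hydrogen on an aromatic carbon).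

Going by the values given here, no measured step adds a chloro, so the evidence is indirect. The closest guide is a 1.2-fold lower number from compound 1 to compound 3 (0.08 log units; within the scatter), an exchange of one substituted phenyl group for another. The larger steps, an at least 2.9-fold higher number from compound 1 to compound 2 (0.46 log units; beyond the scatter) and an at least 3.4-fold lower number from compound 2 to compound 3 (0.54 log units; beyond the scatter), both involve cyclohexyl, a far bigger change than this one. Compound 4 keeps its phenyl group, so no step beyond the scatter is expected in this assay. The expected step is a 1.4-fold lower number from compound 3 to compound 4 (0.13 log units; within the scatter). For compound 4 the estimated value is 8500 nM, with an expected range from 3000 nM to 22000 nM.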

Compound 4, half-maximal inhibitory concentration: 11300 nM
Compound 4: middle estimate off by 1.3-fold (0.12 log units), on the low side, and the stated range covers the measured number.
By their numbers in this assay, from the lowest: compounds 4, 3 and 1 (each within the scatter of the next). At a limit, above all of these: compound 2.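

In this assay, for the compounds shown here, the chloro on the aromatic carbon ortho to a methyl group is the first added atom on this phenyl group, and it gives a 1.0-fold lower number from compound 3 to compound 4 (0.01 log units; within the scatter), so this position takes a chloro with no readable change; the comparison with the 2-methoxyphenyl compound agrees, at a 1.2-fold lower number from compound 1 to compound 4 (0.08 log units; within the scatter). Compound 2 is a limit and not a number: the limit of > 40000 nM in this assay, at which 1 of the 4 values shown sits. With that limit in mind, the gap to the cyclohexyl compound survives the added chloro, at an at least 3.5-fold lower number from compound 2 to compound 4 (0.54 log units; beyond the scatter).

The compounds shown leave open whether an amine or a carboxylic acid on this same aromatic carbon would move the number beyond the scatter. They also leave open whether 3-chlorophenyl, with the chloro but without the methyl, would sit with compound 3 and compound 4.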